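Swapping Trifluoromethyl for Chloro on the Aryl Ring

A few compounds are considered here, and "the series" means these few. Any claim that something is new, unique, unknown or untested is made for them only; others in the source may bear on it.

Of the compounds shown here, two sharing one core have been tested in a functional assay on the whole organism (strain Swiss) with Mus musculus as the target, in the maximal electroshock model, with a stated time of 0.25 h, at a dose of 300 mg/kg by the intraperitoneal route; a higher number here means a stronger effect of the compound at the dose given, a lower number a weaker effect. Compound 1, `CC(C(=O)N1CCN(c2ccccc2)CC1)N1C(=O)CCC1=O`, carries an unsubstituted phenyl ring and gives 100% in this assay. Compound 2, `CC(C(=O)N1CCN(c2cccc(C(F)(F)F)c2)CC1)N1C(=O)CCC1=O`, gives 75% in this assay. Among the compounds with values here, the single measured step between them, a number 25 percentage points lower from compound 1 to compound 2 (beyond the scatter), places compound 2 as the lower of the two numbers, with compound 1 the only neighbour for comparison.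

Compound 3, `CC(C(=O)N1CCN(c2cccc(Cl)c2)CC1)N1C(=O)CCC1=O`, has not yet been measured. It differs from compound 2 by chloro in place of trifluoromethyl on an aromatic carbon. Within the data shown here, the only measured step that bears on this position is the one from compound 1 to compound 2, in which trifluoromethyl entering in place of hydrogen cost a modest amount of activity. Among the measured compounds shown here, no measured step describes chloro at this place, so the direction of the change can only be guessed from the fact that the substituted ring in compound 2 sits below the unsubstituted ring in compound 1. A small recovery toward compound 1 is expected, with the step of a number 10 percentage points higher from compound 2 to compound 3 (within the scatter). Compound 3 is therefore estimated to give 85% in this assay, within a range from 60% to 100%.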

Compound 3, a percentage reported as activity, at one dose (the size of the read-out at that dose, not a potency): 75%
Beside the measured number, compound 3's estimate is 10 percentage points above it; low and high end bracket the measured number.
By their numbers in this assay, from the lowest: compounds 2 and 3 (each within the scatter of the next); then compound 1.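

In this assay, chloro in place of trifluoromethyl on this aromatic carbon gives no change at the digits printed from compound 2 to compound 3 (within the scatter), so a substituent of one heavy atom and one of four heavy atoms read alike at this place. Chloro in place of hydrogen gives a number 25 percentage points lower from compound 1 to compound 3 (beyond the scatter), a step of the same size as a number 25 percentage points lower from compound 1 to compound 2 (beyond the scatter), which shows that the loss from the unsubstituted ring of compound 1 is not confined to trifluoromethyl, as both substituted compounds shown follow it. Nothing available explains why these two different groups give the same result.

The compounds shown leave open whether a group of another kind on this carbon, such as an amine, a carboxylic acid or a longer chain, would bring the same step, and whether chloro or trifluoromethyl would behave alike on other carbons of the ring. On these data alone, the read-out also gives the size of the effect at one dose rather than a potency, so it remains open whether compound 2 and compound 3 would still read alike at other doses.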